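A few compounds are considered here, and "the series" means these few. Any claim that something is new, unique, unknown or untested is made for them only; others in the source may bear on it.

- Compound 1 `O=C(Nc1ccc(C(F)(F)F)cc1)c1cc(Cl)ccc1O`: 510 nM
- Compound 2 `O=C(Nc1ccc(C(F)(F)F)cc1)c1cc(Cl)c(-c2ccccc2)cc1O`: 490 nM
- Compound 3 `O=C(Nc1ccc(C(F)(F)F)cc1)c1cc(Br)ccc1O`: 580 nM

In a functional assay on HL-60 cells (Homo sapiens) for cytotoxicity, read by luminescence and CellTiter-Glo, with a stated time of 3 days (on this read-out higher numbers stand for weaker inhibition and lower numbers for stronger inhibition), compound 1 stands within the scatter of both other compounds, at 510 nM. Compound 4 `O=C(Nc1ccc(C(F)(F)F)c(Cl)c1)c1cc(Cl)ccc1O` differs from compound 1 by chloro in place of hydrogen on an aromatic carbon. The change is chloro in place of hydrogen on an aromatic carbon. Among the compounds with values here, two measured steps bear on it only indirectly: a 1.0-fold lower number from compound 1 to compound 2 (0.02 log units; within the scatter), and a 1.1-fold higher number from compound 1 to compound 3 (0.06 log units; within the scatter). Both are small, and neither changes the carbon at issue. No step beyond the scatter is therefore expected in this assay, though a slightly lower number is possible. The step expected is a 1.4-fold lower number from compound 1 to compound 4 (0.14 log units; within the scatter). For compound 4 the estimated value is 370 nM, with an expected range of 140 nM to 850 nM.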

Compound 4, half-maximal inhibitory concentration: 460 nM
Estimate against measurement, compound 4: 1.2-fold (0.09 log units) below; low and high end bracket the measured number.
By their numbers in this assay, from the lowest: compounds 4, 2, 1 and 3 (each within the scatter of the next).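

In this assay, chloro in place of hydrogen on the aromatic carbon ortho to the trifluoromethyl group gives a 1.1-fold lower number from compound 1 to compound 4 (0.04 log units; within the scatter). Within the data shown here, the earlier steps changed the other aromatic ring, so this is the first sign that the ring carrying the trifluoromethyl group also accepts a substituent with no step beyond the scatter. Only this one position and this one atom are covered. On these data alone, whether an amine, a methoxy group or a carboxylic acid on this carbon would move the number beyond the scatter stays open. No measurement shown offers an explanation for this result.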